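Swapping a trimethylphenyl for a chlorophenyl

The compounds below may be only part of what the source reports. "The series", "measured", "known", "first", "only" and "open" are said of these compounds alone.

Measured so far in an assay for inhibition of protein disulfide-isomerase (Homo sapiens), with a stated time of 1 h; on this read-out higher numbers stand for weaker inhibition and lower numbers for stronger inhibition:
Compound 1 `CCc1ccc(C(Nc2ccccn2)c2ccc3cccnc3c2O)cc1` gives 170 nM.
Compound 2 `Cc1ccc(C(Nc2ccccn2)c2ccc3cccnc3c2O)cc1` gives 460 nM.
Compound 3 `Cc1cc(C)c(C(Nc2ccccn2)c2ccc3cccnc3c2O)c(C)c1` gives 190 nM.

Compound 3 stands second highest of the three numbers. Its distance from compound 1 is within the scatter (a 1.1-fold higher number from compound 1 to compound 3 (0.05 log units; within the scatter)), while its distance from compound 2 is beyond it (a 2.4-fold lower number from compound 2 to compound 3 (0.38 log units; beyond the scatter)).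

Compound 4 `Oc1c(C(Nc2ccccn2)c2ccc(Cl)cc2)ccc2cccnc12` differs from compound 3 in one place: 4-chlorophenyl in place of 2,4,6-trimethylphenyl on a saturated chain carbon bound to an aromatic carbon and a nitrogen on an aromatic ring. Two measured steps change the same place, the aryl group on that chain carbon: a 1.1-fold higher number from compound 1 to compound 3 (0.05 log units; within the scatter) and a 2.4-fold lower number from compound 2 to compound 3 (0.38 log units; beyond the scatter). A third step, a 2.7-fold higher number from compound 1 to compound 2 (0.43 log units; beyond the scatter), shows that even one methyl on that aryl shifts the number modestly. Going by the values given here, no measured compound carries chlorine, so the closest guide is that 4-chlorophenyl is named in the same pattern as the 4-methylphenyl of compound 2 and the 4-ethylphenyl of compound 1, whose numbers bracket compound 3 on both sides.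

Compound 4 is therefore expected to show a 1.6-fold higher number from compound 3 to compound 4 (0.20 log units; within the scatter), a rise of modest size that may not clear the scatter. Compound 4 is estimated at 300 nM, with a range from 120 nM to 750 nM.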

Compound 4, half-maximal inhibitory concentration: 170 nM
Compound 4: the middle estimate sits 1.8-fold (0.25 log units) above what was measured; low and high end bracket the measured number.
By their numbers in this assay, from the lowest: compounds 1, 4 and 3 (each within the scatter of the next); then compound 2.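

Putting 4-chlorophenyl in place of 2,4,6-trimethylphenyl on this saturated chain carbon leaves the result within the scatter (a 1.1-fold lower number from compound 3 to compound 4 (0.05 log units; within the scatter)), so an aryl group carrying chlorine reads like the trimethylphenyl group here. Chloro in place of methyl on the aromatic carbon lowers the number (a 2.7-fold lower number from compound 2 to compound 4 (0.43 log units; beyond the scatter)), while chloro in place of ethyl gives a level result (no change at the digits printed from compound 1 to compound 4 (within the scatter)), so among these four compounds only compound 2, with its single methyl, stands apart. No measurement shown explains why such different groups read alike or why compound 2 differs.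

The aryl groups shown carry only chloro, methyl or ethyl, so it remains open how an amine, a carboxylic acid or a longer chain on that ring would read. The shared core stays the same throughout, so it is also unknown whether this pattern would hold on a changed core.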